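Cytotoxicity of a chalcone amide series on Vero cells

The compounds below may be only part of what the source reports. "The series", "measured", "known", "first", "only" and "open" are said of these compounds alone.

Compound 3 `COC(=O)c1cc(-c2cccc(NC(=O)c3ccc(/C=C/C(=O)c4ccccc4O)cc3)c2)on1` carries a 2-hydroxyphenyl group on its carbonyl; in an ADME assay on Vero cells (Chlorocebus sabaeus) for cytotoxicity, read by MTT assay, with a stated time of 72 h (a higher number here means that more compound is tolerated, a lower number that less compound is tolerated), compound 3 gives "not determined" (no result reported), so it stands without a number. The two related values are limits: compound 1 `CCCOc1ccc(C(=O)/C=C/c2ccc(C(=O)Nc3cccc(-c4cc(C(=O)OC)no4)c3)cc2)cc1` gives > 40 ug/mL in this assay, a limit rather than a number. Compound 2 `COC(=O)c1cc(-c2cccc(NC(=O)c3ccc(/C=C/C(=O)c4ccc(OC)cc4)cc3)c2)on1` gives > 10 ug/mL in this assay, also a limit. The step that the two limits leave unreadable from compound 1 to compound 2 therefore cannot be read. Compound 4 `COC(=O)c1cc(-c2cccc(NC(=O)c3ccc(/C=C/C(=O)c4cccc(OC)c4)cc3)c2)on1` differs from compound 3 by 3-methoxyphenyl in place of 2-hydroxyphenyl on a carbonyl carbon. Going by the values given here, no measured step bears on this change, and the only evidence is the limit of > 10 ug/mL in this assay, at which 1 of the 3 values shown sits, and (the limit of > 40 ug/mL in this assay, at which 1 of the 3 values shown sits), both tolerances with no toxicity seen. For compound 4 the expected value in this assay is 40 ug/mL, with a range of 10 ug/mL to 100 ug/mL.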

Compound 4, half-maximal cytotoxic concentration: > 100 ug/mL
Compound 4: no number, only a limit; the forecaster's own chance of this, stated with the estimate: 70%; middle value at least 2.5-fold (0.39 log units) from the limit.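

Compound 1, compound 2 and compound 4 each give only a limit in this assay, so the steps from compound 2 and compound 1 to compound 4 cannot be read. The compounds shown leave open whether 3-methoxyphenyl and 4-methoxyphenyl differ in how much compound the cells tolerate.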